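Swapping an octyl chain for a methylphenyl group on a shared core

The compounds below may be only part of what the source reports. "The series", "measured", "known", "first", "only" and "open" are said of these compounds alone.

All three measured compounds share one core, and the piece concerns how far a change on its side chain moves the read-out of an ADME assay on HEL cells (Homo sapiens) for cytotoxicity, with a stated time of 3 days; on this read-out higher numbers stand for lower toxicity in this test and lower numbers for higher toxicity in this test. Compound 2 has the structure `CCCCCCCCCCc1cc2cn([C@H]3C[C@H](O)[C@@H](CO)O3)c(=O)nc2o1`. In this assay compound 2 gives >= 130000 nM, which is a limit of the assay and not a number, as stated in the limit of >= 130000 nM in this assay, at which 1 of the 3 values shown sits. Compound 1, with the structure `CCCC#Cc1ccc(-c2cc3cn([C@H]4C[C@H](O)[C@@H](CO)O4)c(=O)nc3o2)cn1`, also reaches a limit, giving >= 100000 nM in this assay, as the limit of >= 100000 nM in this assay, at which 1 of the 3 values shown sits, records. Compound 3, with the structure `CCCc1ccc(C#Cc2cc3cn([C@H]4C[C@H](O)[C@@H](CO)O4)c(=O)nc3o2)cc1`, gives a number in this assay, 87000 nM.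

Compound 4 has the structure `Cc1ccc(CCc2cc3cn([C@H]4C[C@H](O)[C@@H](CO)O4)c(=O)nc3o2)cc1` and has not yet been measured in this assay. It differs from compound 2 by 4-methylphenyl in place of octyl on a saturated chain carbon, two bonds along the chain from an aromatic carbon. Going by the values given here, no step between measured compounds is available to set a scale for this change. Since all three measured values lie close to one another and two of them are limits, no movement beyond the scatter is expected in this assay, and the step from compound 2 to compound 4 is estimated as an at least 1.3-fold lower number from compound 2 to compound 4 (0.11 log units; that floor lies within the scatter). Compound 4 is therefore expected to give about 100000 nM in this assay, between 40000 nM and 250000 nM, and the assay may again report only a limit.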

Compound 4, minimum cytotoxic concentration: 540000 nM
Beside the measured number, compound 4's estimate is 5.4-fold (0.73 log units) below it; the whole stated range lies below it.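

The step from compound 2 to compound 4 cannot be read, because the value of compound 2 is a limit of the assay and not a number: the limit of >= 130000 nM in this assay, at which 1 of the 4 values shown sits.

The compounds shown leave open how far, and in which direction, 4-methylphenyl in place of octyl on a saturated chain carbon moves the minimum cytotoxic concentration.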